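Replacing 3-carboxyphenyl with (nitrooxy)methyl on an amide nitrogen

A few compounds are considered here, and "the series" means these few. Any claim that something is new, unique, unknown or untested is made for them only; others in the source may bear on it.

Going by the values given here, in a functional assay on CLL cells (Homo sapiens) for cytotoxicity, read by MTT assay, with a stated time of 48 h (a higher number here means that more compound is needed for the effect, a lower number that less compound is needed), compound 1 `C=C(CC)C(=O)c1ccc(OCC(=O)Nc2cccc(C(=O)O)c2)c(Cl)c1Cl` gives 20600 nM and this is the only exact number so far. Compound 2 `C=C(CC)C(=O)c1ccc(OCC(=O)Nc2nc(/C(=N\OC)C(=O)O)cs2)c(Cl)c1Cl` gives > 25000 nM as its reading, which is a limit of the assay and not a number. Compound 1 therefore has no exact value to be ranked against.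

The next compound to be tested is compound 3 `C=C(CC)C(=O)c1ccc(OCC(=O)NCO[N+](=O)[O-])c(Cl)c1Cl`. It keeps the core of compound 1 but carries (nitrooxy)methyl in place of 3-carboxyphenyl on an amide-type nitrogen, a swap counted as (nitrooxy)methyl in place of 3-carboxyphenyl on an amide-type nitrogen in full. The ring of the leaving group is thus gone, and the entering group has no ring.

Among the compounds with values here, no step between measured compounds is available to guide a forecast, so the range must stay wide. Compound 1 at 20600 nM already needs a large amount of compound, and a move towards a lower number is the likelier outcome. The expected change is a 3.4-fold lower number from compound 1 to compound 3 (0.54 log units; beyond the scatter) and would lie beyond the usual scatter. For compound 3 the estimated value is 6000 nM with an expected range from 1500 nM to 20000 nM in this assay once it is tested.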

Compound 3, half-maximal effective concentration: 4100 nM
Compound 3: middle estimate off by 1.5-fold (0.17 log units), on the high side; measured number inside the range.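

In this assay, going by these compounds alone, the group on the amide-type nitrogen proves to matter: placing (nitrooxy)methyl there in place of 3-carboxyphenyl gives a 5.0-fold lower number from compound 1 to compound 3 (0.70 log units; beyond the scatter), the first step that can be read. The position therefore does not depend on keeping the aromatic ring of compound 1, as compound 3 has no ring in this group and needs less compound for the effect. Compound 2 adds no step to this picture, as its reading is a limit of the assay and not a number: the limit of > 25000 nM in this assay, at which 1 of the 3 values shown sits.

From the compounds shown here alone, the swap removes the ring and the carboxylic acid and brings in the nitrooxy group in a single move, so it remains open which of these changes carries the step, and a plain phenyl group on the same nitrogen would separate the ring from the carboxylic acid. Likewise, a simple methyl or hydroxymethyl group, or a longer chain still carrying the nitrooxy group, would show whether the nitrooxy group itself matters or whether a small open chain is enough.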